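A few compounds are considered here, and "the series" means these few. Any claim that something is new, unique, unknown or untested is made for them only; others in the source may bear on it.

Among the compounds with values here, compound 2 `CC(C)c1onc(-c2c(Cl)cccc2Cl)c1COc1ccc(-c2nc3ccc(C(=O)O)cc3n2C2CCCC2)cc1` is the stronger of the two compounds measured so far: in an assay on HEK-293T cells for antagonist activity at vitamin D3 receptor (Homo sapiens), read by a luciferase reporter, with a stated time of 24 h (a lower number here means a stronger inhibitor, a higher number a weaker inhibitor), compound 2 gives 929 nM, while compound 1 `CCC(CC)n1c(-c2ccc(OCc3c(-c4c(Cl)cccc4Cl)noc3C(C)C)cc2)nc2ccc(C(=O)O)cc21` gives 5690 nM. Within the data shown here, the only step seen so far, a 6.1-fold lower number from compound 1 to compound 2 (0.79 log units; beyond the scatter), came from putting cyclopentyl in place of pentan-3-yl on an aromatic nitrogen. Compound 3 `CC(C)c1onc(-c2c(Cl)cccc2Cl)c1COc1ccc(-c2nc3ccc(C(=O)O)cc3n2C2CCCCCC2)cc1` carries the next change at the same nitrogen: cycloheptyl in place of cyclopentyl on an aromatic nitrogen. The earlier step swapped an open chain for a ring of the same size; here the ring simply grows by two carbons, so that step is only a loose guide, and no measurement shows what a larger ring does. A step of no size beyond the scatter is therefore expected, as a 1.2-fold higher number from compound 2 to compound 3 (0.07 log units; within the scatter). Compound 3 is estimated to give 1100 nM in this assay, within a range from 300 nM to 4000 nM.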

Compound 3, half-maximal inhibitory concentration: 921 nM
The estimate for compound 3 lay 1.2-fold (0.08 log units) above the measured number; low and high end bracket the measured number.
By their numbers in this assay, from the lowest: compounds 3 and 2 (each within the scatter of the next); then compound 1.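

Moving from a five-membered to a seven-membered carbon ring on this aromatic nitrogen gives a 1.0-fold lower number from compound 2 to compound 3 (0.00 log units; within the scatter) in this assay, so across these two rings the number does not follow the count of ring carbons. Cycloheptyl in place of the open-chain pentan-3-yl gives a 6.2-fold lower number from compound 1 to compound 3 (0.79 log units; beyond the scatter), a step much like a 6.1-fold lower number from compound 1 to compound 2 (0.79 log units; beyond the scatter), and so in these three compounds both rings give lower numbers than the open chain, with no compound going against this. Nothing available explains why the two rings give such close numbers or why both differ from the open chain.

The compounds shown leave open whether cyclohexyl or a smaller ring such as cyclobutyl would give a number close to those of the two rings. They also leave open what a ring holding an oxygen atom or an amine would do at this nitrogen.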